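Pyridin-3-yl in Place of Phenyl on a Shared Core

The source may report more compounds than this note shows. Statements on the series, on what has been measured and on what is new or still open speak of the compounds shown alone.

Compound 2 `Oc1cccc(-c2cc(-c3ccccc3)nc(-c3ccccc3)c2)c1` stands highest of the two compounds measured in an assay on isolated protein for inhibition of DNA topoisomerase 1 (Homo sapiens), with a stated time of 30 min, tested at 100 uM (a higher number here means a stronger effect of the compound at the concentration tested, a lower number a weaker effect), where compound 2 gives 11.5%. Its nearest neighbour is compound 1 `Oc1ccccc1-c1cc(-c2ccccc2)cc(-c2ccccc2O)n1`; in this assay compound 1 gives 0%, a gap beyond the usual scatter. Compound 3 `Oc1cccc(-c2cc(-c3ccccc3)nc(-c3cccnc3)c2)c1` has not yet been measured. It differs from compound 2 in one place: pyridin-3-yl in place of phenyl on an aromatic carbon. Among the compounds with values here, no measured pair isolates this exchange, so the step of a number 0.5 percentage points higher from compound 2 to compound 3 (within the scatter) is expected to be small, none beyond the scatter. Compound 3 is therefore estimated at 12%, within a range from 0% to 30%.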

Compound 3, a percentage reported as inhibition, at one concentration (the size of the read-out at that concentration, not a potency): 8.1%
Beside the measured number, compound 3's estimate is 3.9 percentage points above it; low and high end bracket the measured number.
By their numbers in this assay, from the lowest: compounds 1, 3 and 2 (each within the scatter of the next, the first and the last beyond it).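

In this assay, within the data shown here, pyridin-3-yl in place of phenyl, on the aromatic carbon next to the ring nitrogen, gives a number 3.4 percentage points lower from compound 2 to compound 3 (within the scatter), the first measured pair to isolate this exchange. This position therefore accepts a ring with one hetero atom and one hydrogen-bond acceptor without a step beyond the scatter, although neither compound gives a large read-out at the concentration tested. No measurement at hand explains this result. The compounds shown leave open whether pyridin-4-yl, or a phenyl group carrying an amine or a carboxylic acid, would give a step beyond the scatter at this position.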